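Methyl on the ring amide nitrogen: compound 3 to compound 4

This account rests on a few compounds, and the source may have more. Where it says the series, first, only, none or still open, it means among the compounds named here.

Working notes on the series. Of the compounds shown here, three have been measured in a functional assay on the whole organism (strain Wister albino) for inhibition, with Rattus norvegicus as the target, read by paw edema, with stated times of 1 h and 4 h, at a dose of 50 mg/kg by the intraperitoneal route; a lower number here means less inhibition, a higher number more inhibition at the dose given (going by the name of the read-out): compound 1 `CN1C/C(=C\c2ccccc2)C(=O)[C@]2(C1)[C@@H](c1ccccc1)CN(C)[C@@]21C(=O)Nc2ccccc21`, compound 2 `CN1C/C(=C\c2ccc(Br)cc2)C(=O)[C@]2(C1)[C@@H](c1ccc(Br)cc1)CN(C)[C@@]21C(=O)Nc2ccccc21` and compound 3 `CN1C/C(=C\c2ccc(Cl)cc2)C(=O)[C@]2(C1)[C@@H](c1ccc(Cl)cc1)CN(C)[C@@]21C(=O)Nc2ccccc21`. In this assay compound 1 gives 126%, compound 2 gives 118% and compound 3 gives 74.7%. Compound 3 thus stands lowest of the three numbers; its nearest neighbour is compound 2, whose number lies higher by a margin beyond the scatter, and the furthest is compound 1, also higher beyond the scatter. For the measured compounds named here, compound 1 and compound 2 each differ from compound 3 in more than one place, so no single-change step between measured compounds is available, and no pattern for any one change can be drawn from these three numbers.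

Compound 4 `CN1C/C(=C\c2ccc(Cl)cc2)C(=O)[C@]2(C1)[C@@H](c1ccc(Cl)cc1)CN(C)[C@@]21C(=O)N(C)c2ccccc21` has not yet been measured in this assay. Relative to compound 3 it shows (methyl in place of hydrogen on an amide-type nitrogen in a ring). Nothing in the measured set probes this change, so no direction can be taken from the data. The step of a number 2.7 percentage points lower from compound 3 to compound 4 (within the scatter) is expected to be small, without a direction beyond the scatter. Compound 4 is therefore estimated at 72%, with an expected range from 40% to 105% in this assay.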

Compound 4, a percentage reported as inhibition, in the whole organism at one dose (the size of the read-out at that dose, not a potency): 80.9%
For compound 4 the middle estimate is 8.9 percentage points below the measured one, within the range that was stated.
By their numbers in this assay, from the lowest: compounds 3 and 4 (each within the scatter of the next); then compounds 2 and 1 (each within the scatter of the next).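

In this assay, for the compounds shown here, the first single-change step, methyl in place of hydrogen on an amide-type nitrogen in a ring, gives a number 6.2 percentage points higher from compound 3 to compound 4 (within the scatter). At this position, on the background of compound 3, the amide hydrogen can therefore be replaced by methyl without a shift beyond the scatter, so the read-out at this dose does not depend on that hydrogen in this pair. No measurement at hand bears on why the step is this small.

Going by these compounds, whether methyl at this nitrogen behaves the same way on the backgrounds of compound 1 and compound 2 remains open. Also open, on these data alone, is whether a larger group at this nitrogen, such as ethyl, benzyl or acetyl, would stay within the scatter of compound 3.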